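Difluoromethyl in place of ethyl on compound 2

The compounds below may be only part of what the source reports. "The series", "measured", "known", "first", "only" and "open" are said of these compounds alone.

Two compounds have numbers so far in an ADME assay on the whole organism (Mus musculus, strain CD-1) for pharmacokinetics; on this read-out lower numbers stand for slow clearance and higher numbers for fast clearance
compound 1 `CCOc1cc([C@](O)(CCN(C)C)[C@H](c2cccc(C)c2)c2cc3cc(Br)ccc3nc2OC)cc(OC)n1` gives 12 mL/min/kg
compound 2 `CCOc1cc([C@](O)(CCN(C)C)[C@@H](c2cc3cc(Br)ccc3nc2OC)c2ccnc(OC)c2OC)cc(OC)n1` gives 9.5 mL/min/kg

With only these two numbers, compound 2 stands within the usual scatter of compound 1, and neither can be ranked ahead of the other. Compound 3 `COc1cc([C@](O)(CCN(C)C)[C@@H](c2cc3cc(Br)ccc3nc2OC)c2ccnc(OC)c2OC)cc(OC(F)F)n1` has no number yet. It differs from compound 2 by difluoromethyl in place of ethyl on an oxygen on an aromatic ring. Within the data shown here, the one measured step shows a 1.3-fold lower number from compound 1 to compound 2 (0.10 log units; within the scatter) within the scatter, but it swaps 2,3-dimethoxypyridin-4-yl for 3-methylphenyl at another place in the molecule. Among the measured compounds shown here, no measured step touches the group on that oxygen, so the data give no size for this change and no direction for it in this assay either. The expectation therefore rests on compound 2 at 9.5 mL/min/kg as the starting number. The expected step is a 1.1-fold higher number from compound 2 to compound 3 (0.02 log units; within the scatter) and it is not expected to go beyond the scatter. Compound 3 is expected at 10 mL/min/kg (estimated range 4.5 mL/min/kg to 22 mL/min/kg).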

Compound 3, clearance: 8.7 mL/min/kg
Compound 3: the middle estimate sits 1.1-fold (0.06 log units) above what was measured, and the stated range covers the measured number.
By their numbers in this assay, from the lowest: compounds 3, 2 and 1 (each within the scatter of the next).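

In this assay, the group on this oxygen on an aromatic ring now has a measured step of its own, whereas the earlier step concerned another place in the molecule. Going from ethoxy to difluoromethoxy gives a 1.1-fold lower number from compound 2 to compound 3 (0.04 log units; within the scatter), so this exchange of an ethyl for a difluoromethyl, with its two fluorine atoms, moves the read-out no further than the scatter in this one matched pair. Nothing shown explains this outcome, and no supporting measurement bears on it.

From the compounds shown here alone, it remains open whether other groups on the same oxygen, such as trifluoromethyl, cyclopropyl or a longer chain such as propyl, would also stay within the scatter of compound 2 in this assay. Going by these compounds, it is equally open whether the change from ethyl to difluoromethyl would read the same on compound 1, which carries 3-methylphenyl in place of the 2,3-dimethoxypyridin-4-yl of compound 2, since this single step comes from only one background.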